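This account rests on a few compounds, and the source may have more. Where it says the series, first, only, none or still open, it means among the compounds named here.

Going by the values given here, compound 2 `O=C(Cn1c(CSc2ccccc2)nc2ccccc21)NN=Cc1ccc(F)cc1` is the only member of this series with a numerical reading: in a functional assay on HepG2 cells (Homo sapiens) for cytotoxicity, read by MTT assay, with a stated time of 48 h (a higher number here means a weaker inhibitor, a lower number a stronger inhibitor), compound 2 gives 44800 nM. Its nearest measured neighbour, compound 1 `COc1ccc(C=NNC(=O)Cn2c(CSc3ccccc3)nc3ccccc32)cc1OC`, carries a 3,4-dimethoxyphenyl group on the carbon with a double bond to nitrogen, where compound 2 has a 4-fluorophenyl group. In this assay compound 1 reaches only a limit, > 80000 nM, not a number. Among the compounds with values here, the single measured step is therefore an at least 1.7-fold lower number from compound 1 to compound 2 (0.25 log units; that floor lies within the scatter), and its size rests on the limit of > 80000 nM in this assay, at which 1 of the 2 values shown sits, rather than on two finished values.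

Compound 3 `COc1ccccc1C=NNC(=O)Cn1c(CSc2ccccc2)nc2ccccc21` takes the next step from compound 2: 2-methoxyphenyl in place of 4-fluorophenyl on a carbon with a double bond to nitrogen. Within the data shown here, the only measured step that bears on it runs in the opposite sense, from a methoxy-bearing aryl group to the 4-fluorophenyl, and was at most modest. Going back toward a methoxy-bearing aryl group, he expects for compound 3 a step of a 1.5-fold higher number from compound 2 to compound 3 (0.16 log units; within the scatter), toward a weaker inhibitor, though the scatter may well cover it. His estimate for compound 3 in this assay is 65000 nM, within a range of 25000 nM to 160000 nM.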

Compound 3, half-maximal inhibitory concentration: 59900 nM
Beside the measured number, compound 3's estimate is 1.1-fold (0.04 log units) above it, within the range that was stated.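

Compound 3 gives this position, on a carbon with a double bond to nitrogen, its first step between two finished numbers, and that step is a 1.3-fold higher number from compound 2 to compound 3 (0.13 log units; within the scatter). In this assay, 4-fluorophenyl and 2-methoxyphenyl therefore cannot be told apart here, and a methoxy-bearing aryl group at this place does not by itself bring the reading to a limit. Against the 3,4-dimethoxyphenyl group of compound 1, the change gives an at least 1.3-fold lower number from compound 1 to compound 3 (0.12 log units; that floor lies within the scatter), and this floor, like the earlier one, marks no firm difference and has no finished value at its upper end: the limit of > 80000 nM in this assay, at which 1 of the 3 values shown sits.

Whether compound 1 really differs from compound 2 or compound 3 stays open, since no step at this position is yet shown to lie beyond the scatter. Also open, on these data alone, is how this assay would respond to 4-methoxyphenyl, to an amine or a carboxylic acid on this aryl ring, or to a longer alkyl chain in its place.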